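Dichlorobenzyl to methylbenzyl on the piperidine acylsulfonamide

The source may report more compounds than this note shows. Statements on the series, on what has been measured and on what is new or still open speak of the compounds shown alone.

Measured so far:
Compound 1 `N#Cc1cc2c(nc1N1CCC(C(=O)NS(=O)(=O)Cc3cc(Cl)cc(Cl)c3)CC1)COC2=O`; in a functional assay (Platelet, plasma) for inhibition, with Homo sapiens as the target (on this read-out lower numbers stand for stronger inhibition and higher numbers for weaker inhibition), compound 1 gives 30500 nM.
Compound 2 `N#Cc1cc2c(nc1N1CC(C(=O)NS(=O)(=O)Cc3ccccc3)C1)COC2=O`; for compound 2 this assay reports only a limit, > 300000 nM.
Compound 3 `CC1(C(=O)NS(=O)(=O)Cc2ccc(Cl)cc2)CCN(c2nc3c(cc2C#N)C(=O)OC3)CC1`; in this assay compound 3 gives 3010 nM.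

Of the two numbers, compound 1 carries the higher one; compound 3 carries the lower, and the gap between the two is beyond the scatter. Compound 2 sits at the limit of > 300000 nM in this assay, at which 1 of the 3 values shown sits. Within the data shown here, compound 2 and compound 3 each differ from compound 1 in more than one place, so their values show only that the compounds differ, not what any single change does.

Compound 4 `Cc1ccc(CS(=O)(=O)NC(=O)C2CCN(c3nc4c(cc3C#N)C(=O)OC4)CC2)cc1` differs from compound 1 in one place: 4-methylphenyl in place of 3,5-dichlorophenyl on a saturated chain carbon bound to a sulfonyl sulfur. No measured pair carries this change on its own, so the step has no direct precedent among these compounds. The step of a 1.3-fold higher number from compound 1 to compound 4 (0.12 log units; within the scatter) is expected to be small, toward a somewhat higher number, within or only just beyond the scatter. Compound 4 is accordingly expected at 40000 nM, with a range from 8000 nM to 200000 nM. Among the measured compounds shown here, with only three measured compounds, one of them at the limit, this estimate is held loosely.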

Compound 4, half-maximal inhibitory concentration: 4280 nM
Compound 4: the middle estimate sits 9.3-fold (0.97 log units) above what was measured; measured number below the stated range.
By their numbers in this assay, from the lowest: compounds 3 and 4 (each within the scatter of the next); then compound 1. At a limit, above all of these: compound 2.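

In this assay, among these compounds, 4-methylphenyl in place of 3,5-dichlorophenyl on a saturated chain carbon bound to a sulfonyl sulfur gives a 7.1-fold lower number from compound 1 to compound 4 (0.85 log units; beyond the scatter), the first step that can be read at a single place. This place is therefore sensitive to the choice of aryl group, and the change from 3,5-dichlorobenzyl to 4-methylbenzyl moves the read-out toward stronger inhibition. The change alters the substituents and their ring locations together, so this one step cannot separate the loss of the two chlorines from the gain of the methyl, and no measurement shown accounts for the step.

Still open, going by these compounds, is whether the gain belongs to 4-methylphenyl in particular or would also appear with a 3-methylphenyl, a 4-methoxyphenyl or a 4-aminophenyl group at the same place. Also open, on these data alone, is whether a carboxylic acid on that ring, or a longer chain between the ring and the sulfonyl sulfur, would keep the read-out of compound 4 at 4280 nM.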